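The compounds below may be only part of what the source reports. "The series", "measured", "known", "first", "only" and "open" are said of these compounds alone.

Measured so far:
compound 1 `O=C1CC(C2CCOCC2)Oc2ccc(S(=O)(=O)N3CCCC3c3ccccc3C(F)(F)F)cc21` — 3.5
compound 2 `CCc1ccc(N(Cc2ccccc2)S(=O)(=O)c2ccc3c(c2)C(=O)CC(C2CCOCC2)O3)cc1` — 4.84
compound 3 `CCc1ccc(N(CC(C)C)S(=O)(=O)c2ccc3oc(C4CCOCC4)cc(=O)c3c2)cc1` — 4.5

In a physicochemical assay for lipophilicity, at pH 7.4 (on this read-out lower numbers stand for lower lipophilicity and higher numbers for higher lipophilicity), compound 2 stands highest of the three numbers. Compound 3 is nearest, lower by a margin beyond the scatter; compound 1 is furthest, lower by a wider margin, also beyond the scatter. Compound 4 `CCc1ccc(N(CC(C)C)S(=O)(=O)c2ccc3c(c2)C(=O)CC(C2CCOCC2)O3)cc1` has not yet been measured in this assay. Compared with compound 2 it differs in one place: isopropyl in place of phenyl on a saturated chain carbon bound to a sulfonamide nitrogen. Going by the values given here, no measured pair shows this same change, so the size of the step is not known from the series. A downward step of moderate size, beyond the scatter, is expected, a number 0.64 log units lower from compound 2 to compound 4 (beyond the scatter). Compound 4 is estimated at 4.2, with a range from 3.8 to 4.6.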

Compound 4, distribution coefficient: 4.21
Compound 4: the middle estimate sits 0.01 log units below what was measured, within the range that was stated.
By their numbers in this assay, from the lowest: compound 1; then compounds 4 and 3 (each within the scatter of the next); then compound 2.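

In this assay, going by these compounds alone, isopropyl in place of phenyl on a saturated chain carbon bound to a sulfonamide nitrogen gives a number 0.63 log units lower from compound 2 to compound 4 (beyond the scatter) in the first single-place pair of the series. This place therefore registers the change, which removes a six-membered aromatic ring and alters no hydrogen-bond donor or acceptor count. No measurement at hand accounts for the step.

A single pair does not show whether the step carries over to another core. From the compounds shown here alone, how a longer chain, an amine or a carboxylic acid would read in this place remains open.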